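Swapping the aryl group on the saturated ring carbon

The source may hold more compounds than are shown below. What is called first, only, known or untested is meant among the compounds shown, and "the series" means these compounds.

Among the compounds with values here, compound 2, `COc1cc(/C=C/C(=O)C2=C(/C=C/c3ccc(O)c(OC)c3)NC(=S)NC2c2ccc(C)cc2)ccc1O`, is the stronger of the two compounds measured so far. In a functional assay, with a stated time of 20 min, tested at 20 uM (a higher number here means a stronger effect of the compound at the concentration tested, a lower number a weaker effect), compound 2 gives 51%, while compound 1, `COc1cc(/C=C/C(=O)C2=C(/C=C/c3ccc(O)c(OC)c3)NC(=O)NC2c2ccccc2)ccc1O`, gives 38.2%, a gap that lies beyond the usual scatter. Compound 3, `COc1cc(/C=C/C(=O)C2=C(/C=C/c3ccc(O)c(OC)c3)NC(=S)NC2c2c(Cl)cccc2Cl)ccc1O`, has not yet been measured. It differs from compound 2 in one place: 2,6-dichlorophenyl in place of 4-methylphenyl on a saturated ring carbon. Within the data shown here, no step of this kind between two measured compounds is available, so the direction of the change cannot be read from earlier pairs. Compound 3 is therefore expected to land close to compound 2, with an estimated step of a number 3 percentage points lower from compound 2 to compound 3 (within the scatter) in this assay, not clearly beyond the scatter in either direction. On that basis compound 3 is estimated at 48%, with a range from 30% to 66%.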

Compound 3, a percentage reported as activity, at one concentration (the size of the read-out at that concentration, not a potency): 43.2%
For compound 3 the middle estimate is 4.8 percentage points above the measured one; measured number inside the range.
By their numbers in this assay, from the lowest: compounds 1, 3 and 2 (each within the scatter of the next, the first and the last beyond it).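

In this assay, within the data shown here, placing 2,6-dichlorophenyl in place of 4-methylphenyl on the saturated ring carbon gives a number 7.8 percentage points lower from compound 2 to compound 3 (within the scatter), the only step so far that isolates this position. The two aryl groups are therefore not separated by this assay at the concentration tested, even though the new group carries two chlorine atoms and the old one a single methyl group. Nothing available explains this result or links it to any property of either group.

The compounds shown leave open whether a different group at this position, such as 4-aminophenyl, 4-carboxyphenyl or a plain alkyl chain, would move the read-out beyond the scatter. They also leave open what exchanging the ring thiocarbonyl for a carbonyl does on its own, with the aryl group held fixed.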